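A few compounds are considered here, and "the series" means these few. Any claim that something is new, unique, unknown or untested is made for them only; others in the source may bear on it.

In an ADME assay on BJ cells (Homo sapiens) for cytotoxicity, with a stated time of 72 h (a lower number here means that less compound is needed, a higher number that more compound is needed for the effect), compound 1 `Cc1cc(NC(=O)Nc2ccc(F)cc2)c2ccccc2n1` reaches only a limit of the assay, > 25000 nM. Compound 2 `Cc1cc(NC(=O)Nc2cccc(F)c2)c2ccccc2n1` likewise stops at a limit, > 25000 nM. Compound 3 `COC(=O)c1ccc(NC(=O)Nc2cc(C)nc3ccccc23)cc1` gives 21000 nM in this assay. The two cores differ in that (3-fluorophenyl in place of 4-fluorophenyl on an amide-type nitrogen), and the step that the two limits leave unreadable from compound 1 to compound 2 cannot be sized given (the limit of > 25000 nM in this assay, at which 2 of the 3 values shown sit). From compound 1 to compound 3 the change is methoxycarbonyl in place of fluoro on an aromatic carbon, giving an at least 1.1-fold lower number from compound 1 to compound 3 (0.07 log units; that floor lies within the scatter). Compound 4 `COC(=O)c1cccc(NC(=O)Nc2cc(C)nc3ccccc23)c1` awaits measurement in this assay; it differs from compound 2 in that (methoxycarbonyl in place of fluoro on an aromatic carbon), the same kind of change, though here the place is meta to a large group where in compound 3 it was para to a large group. The expected step of an at least 1.0-fold lower number from compound 2 to compound 4 (0.01 log units; that floor lies within the scatter) is set beside an at least 1.1-fold lower number from compound 1 to compound 3 (0.07 log units; that floor lies within the scatter), resting on compound 3 with 21000 nM. Compound 4 is thus estimated at 24000 nM.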

Compound 4, half-maximal effective concentration in the BJ assay: 21000 nM
Beside the measured number, compound 4's estimate is 1.1-fold (0.06 log units) above it; the measured number falls inside the stated range.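

In the BJ assay, methoxycarbonyl in place of fluoro gives an at least 1.1-fold lower number from compound 2 to compound 4 (0.07 log units; that floor lies within the scatter). Set beside the same change on the core of compound 1, the step reads alike, but this does not show that its size carries from one core to the other: the same change on two cores in the BJ assay, an at least 1.1-fold lower number (0.07 log units; that floor lies within the scatter) from compound 1 to compound 3 and an at least 1.1-fold lower number (0.07 log units; that floor lies within the scatter) from compound 2 to compound 4; the limit leaves it open whether they differ. In a physicochemical assay for solubility, at pH 7.4 (a higher number here means a more soluble compound, a lower number a less soluble compound), compound 2 gives 100 nM and compound 4 gives 600 nM. The change separates compound 4 from compound 2, yet this rests on a single pair and says nothing about a second core: the measured solubility of compound 2, 100 nM, and of compound 4, 600 nM, a 6.0-fold higher number (0.78 log units; beyond the scatter).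

From the compounds shown here alone, whether the step in the physicochemical assay recurs on the core of compound 1 stays open. So does how a carboxylic acid or an amine on that aromatic carbon would read in the BJ assay.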